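Notes on the step from compound 2 to compound 3

The compounds below may be only part of what the source reports. "The series", "measured", "known", "first", "only" and "open" are said of these compounds alone.

Among the measured compounds shown here, compound 2 `Nc1nc(NCc2ccc(OCCCCC(=O)NO)cc2)nc2nc(-c3ccco3)nn12` stands highest of the two numbers measured so far: in an assay on isolated protein for inhibition of protein deacetylase HDAC6 (Homo sapiens), with a stated time of 15 min (on this read-out higher numbers stand for weaker inhibition and lower numbers for stronger inhibition), compound 2 gives 35 nM. For the measured compounds named here, compound 1 `Nc1nc(NCc2ccc(C(=O)NO)cc2)nc2nc(-c3ccco3)nn12` gives 3 nM in this assay, and the single step known, a 12-fold higher number from compound 1 to compound 2 (1.07 log units; beyond the scatter), came from 4-(hydroxycarbamoyl)butoxy in place of hydroxycarbamoyl on an aromatic carbon. Compound 3 `Nc1ccccc1NC(=O)c1ccc(CNc2nc(N)n3nc(-c4ccco4)nc3n2)cc1` is not yet measured. It differs from compound 2 by (2-aminophenyl)carbamoyl in place of 4-(hydroxycarbamoyl)butoxy on an aromatic carbon, on an aromatic carbon of a six-membered aromatic ring of carbon only, para to a large group. Going by the values given here, only the step from compound 1 to compound 2 bears on this; that step kept a hydroxycarbamoyl, inside the 4-(hydroxycarbamoyl)butoxy, and already gave a large rise, whereas here the hydroxycarbamoyl is removed altogether. A larger step toward weaker inhibition is therefore expected, an 86-fold higher number from compound 2 to compound 3 (1.93 log units; beyond the scatter). Compound 3 is estimated at 3000 nM, with a range from 300 nM to 30000 nM.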

Compound 3, half-maximal inhibitory concentration: > 10000 nM
Compound 3 ended at the assay's limit; the forecaster's own chance of this, stated with the estimate: 30%; middle value at least 3.3-fold (0.52 log units) from the limit.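

In this assay compound 3 gives > 10000 nM, which is a limit of the assay and not a number: the limit of > 10000 nM in this assay, at which 1 of the 3 values shown sits.

The exchange at this aromatic carbon, para to a large group, therefore has only a lower bound, both for the change of side chain, an at least 280-fold higher number from compound 2 to compound 3 (2.45 log units; beyond the scatter), and for the change on the amide-type nitrogen alone, an at least 3300-fold higher number from compound 1 to compound 3 (3.52 log units; beyond the scatter). The second step adds what compounds 1 and 2 could not show: with the carbonyl kept, 2-aminophenyl in place of hydroxy on that nitrogen is enough to carry the read-out to the limit, a larger change than lengthening to 4-(hydroxycarbamoyl)butoxy gave.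

How far compound 3 lies past the limit stays open, and the values give no reason for the loss. Also open, going by these compounds, is how a carboxylic acid at this position, or a chain between benzene ring and hydroxycarbamoyl shorter than butoxy, would read.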